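Replacing thiophen-2-yl with ethynyl on a shared core

This account rests on a few compounds, and the source may have more. Where it says the series, first, only, none or still open, it means among the compounds named here.

Measured values in an ADME assay on MRC5 cells (Homo sapiens), read by MTT assay, with a stated time of 72 h (a higher number here means a weaker inhibitor, a lower number a stronger inhibitor), are as follows
Compound 1 `COc1ncnc2c1c(-c1ccccc1)cn2[C@@H]1O[C@H](CO)[C@@H](O)[C@H]1O` gives > 100000 nM as a limit
Compound 2 `COc1ncnc2c1c(-c1cc3ccccc3o1)cn2[C@@H]1O[C@H](CO)[C@@H](O)[C@H]1O` gives 65600 nM as a number
Compound 3 `CSc1ncnc2c1c(-c1cccs1)cn2[C@@H]1O[C@H](CO)[C@@H](O)[C@H]1O` gives > 100000 nM as a limit

Compound 3 has no number of its own, only the limit > 100000 nM in this assay as its reading. It stands on the limit of > 100000 nM in this assay, at which 2 of the 3 values shown sit, as its place on the scale.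

The next step leads to compound 4 `C#Cc1cn([C@@H]2O[C@H](CO)[C@@H](O)[C@H]2O)c2ncnc(SC)c12` and puts ethynyl in place of thiophen-2-yl on an aromatic carbon with the rest of the molecule unchanged.

Going by the values given here, the one measured step that changes the group on this carbon gives an at least 1.5-fold lower number from compound 1 to compound 2 (0.18 log units; that floor lies within the scatter) and so stays within the scatter at its floor. That step swaps one ring group for another, whereas ethynyl has no ring, so it is only a loose guide. Still, compound 2 with 65600 nM shows that a real number can be reached in this small set. A modest move towards a lower number is therefore expected, not clearly beyond the scatter.

The expected step is an at least 1.6-fold lower number from compound 3 to compound 4 (0.22 log units; that floor lies within the scatter) and it starts from a limit.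

Compound 4 is estimated at 60000 nM (expected range 10000 nM to 100000 nM) in this assay and a reading at the limit would be no surprise.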

Compound 4, half-maximal inhibitory concentration: > 100000 nM
Compound 4: a limit, no number; the forecaster's own chance of this, stated with the estimate: 50%; middle value at least 1.6-fold (0.22 log units) from the limit.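

In this assay compound 4 gives > 100000 nM as a limit and not a number. Compound 3 gives > 100000 nM as a limit too, so the step between compound 3 and compound 4 cannot be read. The compounds shown leave open whether ethynyl or thiophen-2-yl on this carbon gives the lower number.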